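Adding Fluoro to the Anilino Group of Compound 2

A few compounds are considered here, and "the series" means these few. Any claim that something is new, unique, unknown or untested is made for them only; others in the source may bear on it.

Compound 1 `COc1ccc(C(=O)c2sc(Nc3ccc(F)cc3)c(C(=O)O)c2C)cc1`: 0.836%
Compound 2 `Cc1ccc(C(=O)c2sc(Nc3ccccc3)c(C(=O)O)c2C)cc1`: 4.35%

Both compounds were tested in a functional assay, with a stated time of 150 min, tested at 25 ug/mL; a higher number here means a stronger effect of the compound at the concentration tested, a lower number a weaker effect. Compound 2 gives the higher of the two numbers, but the number for compound 1 lies within the usual scatter of it, so the two cannot be told apart. Compound 3 `Cc1ccc(C(=O)c2sc(Nc3ccc(F)cc3)c(C(=O)O)c2C)cc1` has not been measured. Its change from compound 2 is fluoro in place of hydrogen on an aromatic carbon, on an aromatic carbon of a six-membered aromatic ring of carbon only, para to a large group. For the measured compounds named here, no step between measured compounds shows what this exchange alone does, so the step of a number 1.4 percentage points lower from compound 2 to compound 3 (within the scatter) is expected to be none beyond the scatter. Compound 3 is therefore estimated at 3%, within 0% to 12%.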

Compound 3, a percentage reported as activity, at one concentration (the size of the read-out at that concentration, not a potency): "not active" (no number reported)
Compound 3: no number reported; there is nothing to compare the estimate with.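

For the compounds shown here, compound 3 is reported as not active, without a number, so no step from compound 2 to compound 3 can be read. Nothing shown bears on this result. On these data alone, how far fluoro in place of hydrogen alone shifts the read-out in this assay stays open.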